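A few compounds are considered here, and "the series" means these few. Any claim that something is new, unique, unknown or untested is made for them only; others in the source may bear on it.

Among the measured compounds shown here, compound 1 `C/C(=C\CC/C(C)=C/CC[C@@H]1[C@@]2(C)CCC(=O)C(C)(C)[C@H]2CC[C@@]1(C)O)CC/C=C(\C)C(=O)OCc1cn(-c2cccc(O)c2)nn1` is the only member of this small set to return a definite number in a functional assay on DU-145 cells (Homo sapiens) for antiproliferative activity, read by MTT assay, with a stated time of 48 h; on this read-out higher numbers stand for weaker inhibition and lower numbers for stronger inhibition: compound 1 gives 28400 nM. The two other measured compounds sit at a limit of the assay rather than at a number (the limit of > 150000 nM in this assay, at which 2 of the 3 values shown sit). Compound 2 `C/C(=C\CC/C(C)=C/CC[C@@H]1[C@@]2(C)CCC(=O)C(C)(C)[C@H]2CC[C@@]1(C)O)CC/C=C(\C)C(=O)OCc1cn(-c2ccc(F)c(Cl)c2)nn1` reaches only the limit > 150000 nM in this assay. Compound 3 `C/C(=C\CC/C(C)=C/CC[C@@H]1[C@@]2(C)CCC(=O)C(C)(C)[C@H]2CC[C@@]1(C)O)CC/C=C(\C)C(=O)OCc1cn(-c2ccc(Br)cc2)nn1` likewise reaches only the limit > 150000 nM in this assay. Read as steps, there is an at least 5.2-fold higher number from compound 1 to compound 2 (0.72 log units; beyond the scatter) and an at least 5.2-fold higher number from compound 1 to compound 3 (0.72 log units; beyond the scatter), while between the two limits there is a step that the two limits leave unreadable from compound 2 to compound 3.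

Compound 4 `COc1ccc(-n2cc(COC(=O)/C(C)=C/CC/C(C)=C/CC/C(C)=C/CC[C@@H]3[C@@]4(C)CCC(=O)C(C)(C)[C@H]4CC[C@@]3(C)O)nn2)cc1` differs from compound 1 in one place: 4-methoxyphenyl in place of 3-hydroxyphenyl on an aromatic nitrogen. Both measured steps away from compound 1 also exchanged the 3-hydroxyphenyl on the aromatic nitrogen for another phenyl group, and both pushed the result to the limit of this assay, so a step in the same direction is expected for compound 4, with a real chance that it too ends at the limit. Compound 4 is therefore expected to give around 100000 nM in this assay, somewhere between 25000 nM and 400000 nM. That would amount to an expected step of a 3.5-fold higher number from compound 1 to compound 4 (0.55 log units; beyond the scatter).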

Compound 4, half-maximal inhibitory concentration: 135000 nM
Beside the measured number, compound 4's estimate is 1.4-fold (0.13 log units) below it, and the stated range covers the measured number.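

In this assay, the exchange of the 3-hydroxyphenyl now has a measured size and not only a floor: 4-methoxyphenyl in its place gives a 4.8-fold higher number from compound 1 to compound 4 (0.68 log units; beyond the scatter). The group that enters has 0 hydrogen-bond donors where the 3-hydroxyphenyl has 1, with 1 hydrogen-bond acceptor on each side, so compound 4 shows that a phenyl group still carrying an oxygen does not keep the level of compound 1. The comparisons with the two halogen-bearing groups give only an at least 1.1-fold lower number from compound 3 to compound 4 (0.04 log units; that floor lies within the scatter) and an at least 1.1-fold lower number from compound 2 to compound 4 (0.04 log units; that floor lies within the scatter), so compound 4 is not separated from compound 2 or compound 3.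

Compound 4 alters both the group and its position on the phenyl ring, which leaves open whether the hydroxyl itself or its position matters; a 4-hydroxyphenyl, a 3-methoxyphenyl or a 3-aminophenyl on the same nitrogen would pull these apart. The true distance from compound 4 to compound 2 and to compound 3 cannot be read, and neither can the step between compound 2 and compound 3, each of which gives a limit and not a number: the limit of > 150000 nM in this assay, at which 2 of the 4 values shown sit.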